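Arylsulfonylpiperidines: cytotoxicity limits and a methyl removal

This account rests on a few compounds, and the source may have more. Where it says the series, first, only, none or still open, it means among the compounds named here.

Compound 1 `Cc1cc(C)c(S(=O)(=O)N2CCC(c3ccccc3)CC2)c(C)c1`: in an ADME assay on HCT-116 cells (Homo sapiens) for cytotoxicity, read by CellTiter-Glo, with a stated time of 72 h (on this read-out higher numbers stand for weaker inhibition and lower numbers for stronger inhibition), compound 1 gives > 5000 nM, a limit of the assay.
Compound 2 `Cc1ccc(C2CCN(S(=O)(=O)c3c(C)cc(C)cc3C)CC2)cc1`: in this assay compound 2 gives > 5000 nM, again a limit.
Compound 3 `Cc1ccc(S(=O)(=O)N2CCC(N3CCC(C)CC3)CC2)cc1C`: in this assay compound 3 gives > 5000 nM, also a limit.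

All three values sit at the limit of > 5000 nM in this assay, at which 3 of the 3 values shown sit. From compound 2 to compound 1 the change is hydrogen in place of methyl on an aromatic carbon, and the step that the two limits leave unreadable from compound 2 to compound 1. The difference between the cores of compound 2 and compound 3 is not broken down here. Compound 4 `Cc1cccc(S(=O)(=O)N2CCC(N3CCC(C)CC3)CC2)c1` differs from compound 3 by hydrogen in place of methyl on an aromatic carbon, the same kind of change, although here the place is ortho to a methyl group. The step from compound 3 to compound 4 is expected to be a step that the limit leaves unreadable from compound 3 to compound 4, resting on a step that the two limits leave unreadable from compound 2 to compound 1 and on (the limit of > 5000 nM in this assay, at which 3 of the 3 values shown sit). Compound 4 is therefore expected at about 9000 nM, between 4000 nM and 25000 nM, most likely again reported only as a limit.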

Compound 4, half-maximal inhibitory concentration: > 5000 nM
Compound 4: only a limit was reported (the forecaster's own chance of this, stated with the estimate: 85%); the middle value lies beyond the limit too.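

Within the data shown here, compound 3 and compound 4 are both reported only as limits, so no step between them can be read. The compounds shown leave open how strongly each inhibits and whether removing a methyl changes this: the limit of > 5000 nM in this assay, at which 4 of the 4 values shown sit.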